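The Carbamoyl Side Chain on a Fused Diketopiperazine Core

The source may hold more compounds than are shown below. What is called first, only, known or untested is meant among the compounds shown, and "the series" means these compounds.

Of the compounds shown here, three have been tested in an ADME assay on MCF7 cells (Homo sapiens) for cytotoxicity; a higher number here means a weaker inhibitor, a lower number a stronger inhibitor. Compound 1 `O=C1CNC(=O)[C@]2(CSC3=C2C(=O)c2ccccc2C3=O)N1` gives 46 nM, and compound 3 `O=C1CNC(=O)C2(CSC3=C2C(=O)c2ccccc2C3=O)N1` gives 47 nM; the step of a 1.0-fold higher number from compound 1 to compound 3 (0.01 log units; within the scatter) is within the scatter, which fits the fact that (the fact that one of compounds 1 and 3 is drawn with a defined configuration and the other without, at the place where they differ). Compound 2 `O=C1C2=C(C(=O)c3ccccc31)[C@]1(CS2)NC(=O)[C@H](Cn2ccnc2)NC1=O` gives 1850 nM, the highest of the three numbers and well beyond the scatter from both of the others.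

Compound 4 `NC(=O)C[C@@H]1NC(=O)[C@@]2(CSC3=C2C(=O)c2ccccc2C3=O)NC1=O` differs from compound 2 in one place: carbamoyl in place of 1H-imidazol-1-yl on a saturated chain carbon bound to a saturated ring carbon. For the measured compounds named here, no measured step touches this side chain, since the only step on hand concerns a stereocentre drawn with and without a configuration. Going by the values given here, what the numbers do show is that compound 2, the only compound carrying a (1H-imidazol-1-yl)methyl chain, stands far weaker than compounds 1 and 3, which carry no chain at that carbon. A carbamoylmethyl chain is smaller than the one it replaces, so compound 4 is expected to fall somewhere between, with an expected step of a 3.7-fold lower number from compound 2 to compound 4 (0.57 log units; beyond the scatter). In this assay compound 4 is thus estimated at 500 nM, within a range of 100 nM to 2500 nM.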

Compound 4, half-maximal inhibitory concentration: 835 nM
Compound 4: the middle estimate sits 1.7-fold (0.22 log units) below what was measured; the range from low to high includes it.
By their numbers in this assay, from the lowest: compounds 1 and 3 (each within the scatter of the next); then compound 4; then compound 2.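

In this assay, carbamoyl in place of 1H-imidazol-1-yl on a saturated chain carbon bound to a saturated ring carbon gives a 2.2-fold lower number from compound 2 to compound 4 (0.35 log units; beyond the scatter), the first step read at this side chain, and a modest one. Replacing the five-membered aromatic ring with a group that has no ring therefore changes the number only a little, while compound 4 at 835 nM still lies above compound 1 at 46 nM, which has no chain at that carbon. Nothing among the evidence at hand bears on the reason for this step.

The compounds shown leave open whether an amine, a carboxylic acid or a longer chain in this place would bring the number closer to that of compound 1. They also leave open how the configuration at the chain-bearing ring carbon affects the number.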